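The source may report more compounds than this note shows. Statements on the series, on what has been measured and on what is new or still open speak of the compounds shown alone.

Measured compounds in an ADME assay on HepG2 cells (Homo sapiens) for cytotoxicity, read by resazurin assay, with a stated time of 48 h; on this read-out higher numbers stand for an effect only at larger amounts of compound and lower numbers for an effect already at smaller amounts:
compound 1 `Cc1nc(C)c(C(=O)Nc2ccc(F)c(-c3nc4ncc(-c5cccnc5Cl)cn4n3)c2)o1`: > 50000 nM, a limit of the assay
compound 2 `O=C(Nc1ccc(F)c(-c2nc3ncc(-c4cc(F)cc(F)c4)cc3[nH]2)c1)N1CCCC1`: > 50000 nM, a limit of the assay
compound 3 `Cc1nc(C)c(C(=O)Nc2ccc(F)c(-c3nc4ncc(-c5ccccc5Cl)cn4n3)c2)o1`: > 50000 nM, a limit of the assay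

In this assay compound 2 stands only at a limit, and the two other values shown are limits as well, all resting at the limit of > 50000 nM in this assay, at which 3 of the 3 values shown sit. Compound 4 `O=C(Nc1ccc(F)c(-c2nc3ncc(-c4cccc(F)c4F)cc3[nH]2)c1)N1CCCC1` is the compound not yet measured. It differs from compound 2 in one place: 2,3-difluorophenyl in place of 3,5-difluorophenyl on an aromatic carbon. For the measured compounds named here, the single step measured between two compounds that differ in one place, a step that the two limits leave unreadable from compound 1 to compound 3, runs between two limits and so has no readable size. The measured compounds therefore give no indication of how large a shift the move from compound 2 to compound 4 should bring in this assay, nor in which direction. Compound 4 is expected to sit at the limit as well, in keeping with the limit of > 50000 nM in this assay, at which 3 of the 3 values shown sit, and the expected step that the limit leaves unreadable from compound 2 to compound 4 is none beyond the scatter. Compound 4 is estimated at 60000 nM, within a range from 25000 nM to 150000 nM, and most likely reported only as a limit again.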

Compound 4, half-maximal effective concentration: > 50000 nM
Compound 4 ended at the assay's limit; the forecaster's own chance of this, stated with the estimate: 85%; the middle value lies beyond the limit too.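

In this assay compound 4 gives > 50000 nM, a limit of the assay, so no step can be read between it and compound 2, which also rests at a limit. The compounds shown leave open whether 2,3-difluorophenyl and 3,5-difluorophenyl differ at all here, and at what concentration any of the four compounds would show an effect.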